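Dropping the Methoxy Group: Expected Effect on Cell Inhibition

This account rests on a few compounds, and the source may have more. Where it says the series, first, only, none or still open, it means among the compounds named here.

Measured compounds:
- compound 1 `Cc1ccc([N+](=O)[O-])cc1NC(=O)Cn1cc(COc2ccc3c(c2)CCC3)nn1`: "not determined" (no result reported)
- compound 2 `COc1cccc(NC(=O)Cn2cc(COc3ccc4c(c3)CCC4)nn2)c1`: "not determined" (no result reported)
- compound 3 `COc1ccccc1-n1cc(COc2ccc3c(c2)CCC3)nn1`: 19.8%

Three compounds share one core and were considered in an ADME assay on HEK293 cells (Homo sapiens) for inhibition, read by MTT assay, with a stated time of 48 h, tested at 25 uM; on this read-out higher numbers stand for more inhibition at the one concentration tested (going by the name of the read-out) and lower numbers for less inhibition. For compound 1 and compound 2 no number came out of this assay, so neither can be placed. In this assay compound 3 gives 19.8%, and that single figure is the only one available; it describes a modest degree of inhibition at the one concentration tested, and it stands alone, with nothing to rank it against.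

Compound 4 `c1ccc(-n2cc(COc3ccc4c(c3)CCC4)nn2)cc1` is the next compound. It differs from compound 3 by a single change: hydrogen in place of methoxy on an aromatic carbon. Everything else in the molecule stays the same.

Among the measured compounds shown here, no step between two measured compounds is known here, so there is no earlier example to say how this assay reacts to a change of this kind. For the measured compounds named here, with only one number to start from, the expectation is a small step, in no clear direction, and very likely within the usual scatter of repeated measurements. The step is estimated as a number 1.8 percentage points lower from compound 3 to compound 4 (within the scatter). Compound 4 is therefore expected to give about 18% in this assay, with a range from 5% to 32%.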

Compound 4, a percentage reported as inhibition, at one concentration (the size of the read-out at that concentration, not a potency): 23.4%
Compound 4: the middle estimate sits 5.4 percentage points below what was measured, within the range that was stated.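

In this assay, among the compounds shown here, the change from 2-methoxyphenyl to phenyl gives a number 3.6 percentage points higher from compound 3 to compound 4 (within the scatter), and this is the first step that can be read at all. At this place on the aromatic ring, ortho to a large group, swapping methoxy for hydrogen therefore leaves compound 3 and compound 4 indistinguishable on this read-out, so this single pair gives no sign that the methoxy group matters for the result. No independent information is available to explain this outcome.

Any step involving compound 1 or compound 2 cannot be read, so the contribution of the parts that set those two molecules apart from compound 3 and compound 4 stays unknown. One swap at one place also cannot show how the same position would respond to a different group, such as an amine, a carboxylic acid or a longer chain, or whether moving the methoxy group elsewhere on the ring would give a step beyond the scatter.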